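A few compounds are considered here, and "the series" means these few. Any claim that something is new, unique, unknown or untested is made for them only; others in the source may bear on it.

Compound 1 `CNC(=O)c1cc(C(=O)NC2CCC2)cn(Cc2cccc(NC)c2)c1=O`: 3.6
Compound 2 `CNC(=O)c1ccc(=O)n(Cc2cc(Br)ccc2F)c1`: 2.6
Compound 3 `CNC(=O)c1cc(C(=O)NC2CC2)cn([C@H](C)c2ccccc2)c1=O`: 3.4

In a physicochemical assay for lipophilicity, at pH 7.4 (on this read-out higher numbers stand for higher lipophilicity and lower numbers for lower lipophilicity), compound 3 gives 3.4, the second highest of the three numbers. Its nearest neighbour is compound 1, which gives 3.6; that gap lies within the scatter, so the two cannot be ordered. Its furthest neighbour is compound 2, which gives 2.6, a gap beyond the scatter and in the lower direction. Compound 4 `CNC(=O)c1cc(C(=O)NC2CC2)cn(CC2CCCCC2)c1=O` has not yet been measured in this assay. For the measured compounds named here, it differs from compound 3 in one place: cyclohexylmethyl in place of 1-phenylethyl on an aromatic nitrogen No step between two measured compounds with a single change of this kind is available, so the size of the step has to be judged from the change itself and from the value of compound 3. A moderate rise in this assay is expected, a number 0.50 log units higher from compound 3 to compound 4 (beyond the scatter), larger than the scatter but not by much. Compound 4 is therefore estimated at 3.9, with a range from 3.4 to 4.5.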

Compound 4, distribution coefficient: 4
Compound 4: middle estimate off by 0.10 log units, on the low side, within the range that was stated.
By their numbers in this assay, from the lowest: compound 2; then compounds 3 and 1 (each within the scatter of the next); then compound 4.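

With this change the position on the aromatic nitrogen has its first single-place step: in this assay, cyclohexylmethyl in place of 1-phenylethyl gives a number 0.60 log units higher from compound 3 to compound 4 (beyond the scatter). The swap exchanges a six-membered aromatic ring of carbon only for a non-aromatic one and removes the defined stereocentre, while neither group carries hydrogen-bond donors or acceptors. Nothing shown here explains the size or direction of this step.

For the compounds shown here, the single step cannot separate the change of ring from the loss of the stereocentre, and 1-cyclohexylethyl or an unsubstituted benzyl group on the same nitrogen would be needed to tell them apart. As far as these compounds go, how an amine or a carboxylic acid on the cyclohexane ring would behave at this position also remains open.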